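Hydroxycarbamoyl to carboxy on the shared core

The source may report more compounds than this note shows. Statements on the series, on what has been measured and on what is new or still open speak of the compounds shown alone.

In a functional assay on A549 cells (Homo sapiens) for cytotoxicity, read by MTT assay, with a stated time of 48 h (on this read-out lower numbers stand for stronger inhibition and higher numbers for weaker inhibition), compound 1 (`Oc1ccc(NC2CCC3(CC2)OCC2(CO3)C3CC4CC(C3)CC2C4)c2cccnc12`) gives 45600 nM as its measured value. Compound 2 (`O=C(NO)[C@H]1CC[C@@]2(CC1)OC[C@]1(OO2)C2CC3CC(C2)CC1C3`) reads > 50000 nM in this assay and this is a limit of the assay, not a number. Compound 2 thus stands at the limit of > 50000 nM in this assay, at which 1 of the 2 values shown sits, and has no measured position of its own.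

Compound 3 (`O=C(O)[C@H]1CC[C@@]2(CC1)OC[C@]1(OO2)C2CC3CC(C2)CC1C3`) differs from compound 2 by one change (hydroxy in place of hydroxyamino on a carbonyl carbon): hydroxy in place of hydroxyamino on a carbonyl carbon. Within the data shown here, no measured pair shows this change. The expected step that the limit leaves unreadable from compound 2 to compound 3 in this assay is no step beyond the scatter, in either direction. This expectation rests on compound 2, whose reading > 50000 nM is a limit, and on the change itself. For compound 3 the estimate is 60000 nM with an expected range from 30000 nM to 120000 nM and a reading again at the limit is likely.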

Compound 3, half-maximal inhibitory concentration: > 100000 nM
Compound 3: no number, only a limit; the forecaster's own chance of this, stated with the estimate: 75%; middle value at least 1.6-fold (0.22 log units) away from the limit.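

In this assay compound 2 reads > 50000 nM, which is a limit of the assay and not a number. Compound 3 reads > 100000 nM, also a limit, so no step can be read between compound 2 and compound 3. The compounds shown leave open what size, if any, the change from hydroxycarbamoyl to carboxy has in this assay.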